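From 3,5-dimethoxyphenyl to 1H-indol-5-yl on the amine nitrogen

This account rests on a few compounds, and the source may have more. Where it says the series, first, only, none or still open, it means among the compounds named here.

In a functional assay on A549 cells (Homo sapiens) for cytotoxicity, read by MTT assay, with a stated time of 48 h (on this read-out higher numbers stand for weaker inhibition and lower numbers for stronger inhibition), compound 2 (`COc1cc(N/C=C\C(=O)c2c(-c3ccc(Cl)cc3)nc3ccccn23)cc(OC)c1`) gives 9900 nM and compound 1 (`COc1ccc(-c2nc3ccccn3c2C(=O)/C=C\Nc2ccc3[nH]ccc3c2)cc1`) gives 11000 nM, so the two stand within the usual scatter of each other. Compound 3 (`O=C(/C=C\Nc1ccc2[nH]ccc2c1)c1c(-c2ccc(Cl)cc2)nc2ccccn12`) has 1H-indol-5-yl in place of the 3,5-dimethoxyphenyl of compound 2 on an amine nitrogen (1H-indol-5-yl in place of 3,5-dimethoxyphenyl on an amine nitrogen). Among the measured compounds shown here, no measured step isolates this change, but compound 1 also carries 1H-indol-5-yl and gives 11000 nM. No change beyond the scatter is therefore expected in this assay. The expected change is a 1.0-fold higher number from compound 2 to compound 3 (0.00 log units; within the scatter). For compound 3 the estimate is 10000 nM, with an expected range of 4000 nM to 25000 nM.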

Compound 3, half-maximal inhibitory concentration: 1010 nM
Compound 3: the middle estimate sits 9.9-fold (1.00 log units) above what was measured; the measured number lies below the stated range.
By their numbers in this assay, from the lowest: compound 3; then compounds 2 and 1 (each within the scatter of the next).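

In this assay the 1H-indol-5-yl group in place of 3,5-dimethoxyphenyl on the amine nitrogen gives a 9.8-fold lower number from compound 2 to compound 3 (0.99 log units; beyond the scatter) and chloro in place of methoxy on an aromatic carbon gives an 11-fold lower number from compound 1 to compound 3 (1.04 log units; beyond the scatter) with the 1H-indol-5-yl group held in place. The 1H-indol-5-yl group alone, as in compound 1, therefore does not bring the low number, which appears only with chloro in compound 3. No measurement shown explains this. Going by these compounds, whether bromo or fluoro could replace the chloro, or a methyl on the indole nitrogen would keep this number, stays open.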